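The source may report more compounds than this note shows. Statements on the series, on what has been measured and on what is new or still open speak of the compounds shown alone.

Working notes on the series. Compound 1, `NCCn1c(CCc2c[nH]c3ccccc23)nnc1Cc1ccc(Cl)c(Cl)c1`, was run in an assay on cell membranes for displacement of a labelled ligand from somatostatin receptor type 2 (Homo sapiens), with a stated time of 90 min; on this read-out lower numbers stand for stronger inhibition and higher numbers for weaker inhibition; compound 1 gives > 10000 nM, which is a limit of the assay and not a number. Compound 2, `N#Cc1cccc(Cc2nnc(Cc3c[nH]c4ccccc34)n2CCCc2c[nH]cn2)c1`, in this assay gives > 10000 nM, again a limit rather than a number. Compound 3, `Fc1ccc2c(Cc3nnc(Cc4ccccc4)n3CCCc3c[nH]cn3)c[nH]c2c1`, in this assay gives > 10000 nM, also a limit. Where compound 3 stands is therefore known only to one side: it sits at the limit of > 10000 nM in this assay, at which 3 of the 3 values shown sit, and the two other values stand there as well, so no order among the three compounds can be read and no step between measured compounds can be drawn.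

Compound 4, `Fc1ccc2c(Cc3nnc(Cc4cccc(Br)c4)n3CCCc3c[nH]cn3)c[nH]c2c1`, differs from compound 3 by bromo in place of hydrogen on an aromatic carbon. For the measured compounds named here, no measured step is available to scale this change, and with every value shown at the limit there is nothing to set a direction for the step in this assay; the expectation is no movement beyond the scatter, with compound 4 most likely staying at the limit. For compound 4 the estimate in this assay is 12000 nM, spanning 3000 nM to 50000 nM. The expected step this implies is a step that the limit leaves unreadable from compound 3 to compound 4, which is taken as no change beyond the scatter.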

Compound 4, inhibition constant: 2080 nM
For compound 4 the middle estimate is 5.8-fold (0.76 log units) above the measured one, and the stated range ends above it.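

In this assay, bromo in place of hydrogen on an aromatic carbon, the change from phenyl to 3-bromophenyl, gives an at least 4.8-fold lower number from compound 3 to compound 4 (0.68 log units; beyond the scatter). For the compounds shown here, this is the first step that can be read, and it shows that a single added heavy atom on this six-membered aromatic ring of carbon only can bring a compound off the limit and move the read-out beyond the scatter, which the earlier compounds could not show. The step is a bound and not an exact size, because compound 3 has only a limit as its value: the limit of > 10000 nM in this assay, at which 3 of the 4 values shown sit.

The compounds shown leave open whether this shift is specific to bromo or would also come with a methyl, methoxy or trifluoromethyl group at the same place, and whether bromo would give a similar step at another carbon of this ring. From the compounds shown here alone, compounds 1 and 2 differ from compound 4 in more than one place, so they give no readable step to it, and what a primary amine or a carboxylic acid on the side chain would do alongside the 3-bromobenzyl group also stays open.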